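The compounds below may be only part of what the source reports. "The series", "measured", "known", "first", "only" and "open" are said of these compounds alone.

Compound 3 `COc1cccc(/C=C/C(=O)c2sc(Nc3ccccc3C)nc2C)c1` carries a (2-methylphenyl)amino group on its core. In a functional assay on PC-3 cells (Homo sapiens) for cytotoxicity, read by MTT assay (on this read-out higher numbers stand for weaker inhibition and lower numbers for stronger inhibition), compound 3 gives > 25000 nM, which is a limit of the measurement rather than a number. Compound 1 `COc1cccc(/C=C/C(=O)c2sc(Nc3ccc(Cl)cc3)nc2C)c1` differs from it only in the group on that nitrogen. In this assay compound 1 gives > 25000 nM, again a limit. Compound 2 `Cc1ccccc1Nc1nc(C)c(C(=O)/C=C/c2ccc(Cl)cc2)s1` differs from compound 3 only in the aryl group on the double-bonded chain. In this assay compound 2 gives > 25000 nM, also a limit. Among the measured compounds shown here, the step that the two limits leave unreadable from compound 1 to compound 3 and the step that the two limits leave unreadable from compound 2 to compound 3 therefore cannot be sized, since the limit of > 25000 nM in this assay, at which 3 of the 3 values shown sit, and no compound in this set yields a readable number.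

Compound 4 `COc1cccc(/C=C/C(=O)c2sc(Nc3ccc(Cl)c(Cl)c3)nc2C)c1` is the next compound to be measured. It differs from compound 3 in one place: 3,4-dichlorophenyl in place of 2-methylphenyl on a nitrogen on an aromatic ring. For the measured compounds named here, no measured step bears directly on this change, and the two steps that do exist both run between limits. The expectation is that compound 4 behaves like the others, so the step that the limit leaves unreadable from compound 3 to compound 4 is expected to stay within the scatter. The estimate for compound 4 in this assay is 30000 nM, with a range from 10000 nM to 100000 nM, most likely reported again as a limit.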

Compound 4, half-maximal inhibitory concentration: 10100 nM
Beside the measured number, compound 4's estimate is 3.0-fold (0.47 log units) above it; low and high end bracket the measured number.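

In this assay, among the compounds shown here, putting 3,4-dichlorophenyl in place of 2-methylphenyl on the nitrogen produces the first change that can be sized, an at least 2.4-fold lower number from compound 3 to compound 4 (0.39 log units; beyond the scatter). The second step shows that one added chloro is enough, as chloro in place of hydrogen on an aromatic carbon of the group on that nitrogen gives an at least 2.4-fold lower number from compound 1 to compound 4 (0.39 log units; beyond the scatter). So this nitrogen substituent can affect the read-out, and among the compounds shown only compound 4 gives a readable number, with all the others remaining at the limit: the limit of > 25000 nM in this assay, at which 3 of the 4 values shown sit.

Both steps start from a limit, so their full size remains unknown, and these compounds do not show why the 3,4-dichlorophenyl group gives a lower number. Also open, from the compounds shown here alone, is whether a bromo or a trifluoromethyl group in place of the added chloro would give a similar or a larger step, and whether 3,4-dichlorophenyl on the nitrogen would have the same effect with 4-chlorophenyl rather than 3-methoxyphenyl on the double-bonded chain.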